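Replacing an isopropyl with a dimethylisoxazole on the ether-linked ring

The source may hold more compounds than are shown below. What is called first, only, known or untested is meant among the compounds shown, and "the series" means these compounds.

Compound 2, `CCS(=O)(=O)Nc1ccc(Oc2ccc(C(C)C)cc2)c(-c2cn(C)c(=O)c3cncn23)c1`, stands at the bottom of the two numbers available: in an ADME assay on microsomes from liver (Rattus norvegicus) for metabolic stability, with a stated time of 40 min, tested at 10 uM (a lower number here means that less of the compound is left, a higher number that more of the compound is left), compound 2 gives 3.9%, while compound 1, `CCS(=O)(=O)Nc1ccc(Oc2ccc(F)cc2)c(-c2cn(C)c(=O)c3cncn23)c1`, gives 76.2% in this assay. Within the data shown here, the single measured step, a number 72.3 percentage points lower from compound 1 to compound 2 (beyond the scatter), is the only comparison at hand. Compound 3, `CCS(=O)(=O)Nc1ccc(Oc2ccc(-c3c(C)noc3C)cc2)c(-c2cn(C)c(=O)c3cncn23)c1`, differs from compound 2 by 3,5-dimethyl-1,2-oxazol-4-yl in place of isopropyl on an aromatic carbon. Among the measured compounds shown here, no measured step shows an isoxazole entering, so the change is only half covered: the group that leaves is the one whose arrival went with the large fall from compound 1 to compound 2, but what the 3,5-dimethyl-1,2-oxazol-4-yl brings in its stead is unknown. An upward step is therefore expected for compound 3, estimated as a number 31.1 percentage points higher from compound 2 to compound 3 (beyond the scatter), with wide uncertainty. Compound 3 is expected to give about 35% in this assay, plausibly between 8% and 70%.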

Compound 3, percent of the compound remaining: 59.1%
Compound 3: middle estimate off by 24.1 percentage points, on the low side; measured number inside the range.
By their numbers in this assay, from the lowest: compound 2; then compound 3; then compound 1.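

In this assay, the low number of compound 2 proves not to follow from size alone at this position, para to a large group: 3,5-dimethyl-1,2-oxazol-4-yl has more heavy atoms than isopropyl, yet the exchange gives a number 55.2 percentage points higher from compound 2 to compound 3 (beyond the scatter). The same group still falls short of fluoro, with a number 17.1 percentage points lower from compound 1 to compound 3 (beyond the scatter), so most, though not all, of the number lost with isopropyl returns. No evidence at hand accounts for the difference between these groups.

The compounds shown leave open whether the rise belongs to the five-membered aromatic ring itself or to its two methyl groups, which a plain isoxazole would help to separate. They also leave open how a smaller alkyl such as ethyl, or a morpholine, would stand at this position.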